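Swapping an Aryl Amide for an Amino Alcohol Amide

A few compounds are considered here, and "the series" means these few. Any claim that something is new, unique, unknown or untested is made for them only; others in the source may bear on it.

Measured in an ADME assay on L02 cells (Homo sapiens) for antiproliferative activity, read by MTT assay, with a stated time of 48 h; a higher number here means a weaker inhibitor, a lower number a stronger inhibitor:
compound 1 `CCn1c(C(=O)NCCN(C)C)ccc1C(CC)(CC)c1ccc(OCCC(O)(CC)CC)c(C)c1`: 990 nM
compound 2 `CCN(CC)CCNC(=O)c1ccc(C(CC)(CC)c2ccc(OCCC(O)(CC)CC)c(C)c2)n1CC`: 2290 nM
compound 3 `CCOc1ccc(NC(=O)c2ccc(C(CC)(CC)c3ccc(OCCC(O)(CC)CC)c(C)c3)n2CC)cc1`: > 50000 nM

Compound 3 stands at > 50000 nM, which is a limit of the assay and not a number. Its steps from the other two compounds make it the weakest of the three.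

Compound 4 `CCC(C)C(CO)NC(=O)c1ccc(C(CC)(CC)c2ccc(OCCC(O)(CC)CC)c(C)c2)n1CC` keeps the shared core and carries 1-(hydroxymethyl)-2-methylbutyl in place of 4-ethoxyphenyl on the amide-type nitrogen: 1-(hydroxymethyl)-2-methylbutyl in place of 4-ethoxyphenyl on an amide-type nitrogen.

Among the compounds with values here, two measured steps bear most directly on this change, since both remove the same 4-ethoxyphenyl group from the comparison. They are large: an at least 50-fold higher number from compound 1 to compound 3 (1.70 log units; beyond the scatter) and an at least 21-fold higher number from compound 2 to compound 3 (1.33 log units; beyond the scatter). The step of a 2.3-fold higher number from compound 1 to compound 2 (0.36 log units; beyond the scatter) is modest by comparison, so the two amine chains give similar results. Within the data shown here, compound 4 has neither of those chains, and no measured compound shows what its group does. Only part of the large gap is therefore expected to close, with some chance that the result stays at the limit.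

The expected change is an at least 2.5-fold lower number from compound 3 to compound 4 (0.39 log units; beyond the scatter), towards a lower number.

For compound 4 the estimated value in this assay is 20000 nM, with an expected range of 5000 nM to 60000 nM.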

Compound 4, half-maximal inhibitory concentration: > 50000 nM
Compound 4: no number, only a limit (the forecaster's own chance of this, stated with the estimate: 35%); at least 2.5-fold (0.39 log units) between middle value and limit.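

In this assay compound 4 gives > 50000 nM, which is a limit of the assay and not a number. The step from compound 3 to compound 4 cannot be read, and no order between the two can be given, because both stop at the same limit: the limit of > 50000 nM in this assay, at which 2 of the 4 values shown sit.

What compound 4 adds is that replacing 4-ethoxyphenyl on the amide-type nitrogen with a group that has no ring, 1-(hydroxymethyl)-2-methylbutyl, does not bring a readable value, and the gaps to the two amine-chain compounds stay large: an at least 21-fold higher number from compound 2 to compound 4 (1.33 log units; beyond the scatter) and an at least 50-fold higher number from compound 1 to compound 4 (1.70 log units; beyond the scatter). Among these four compounds, only the 2-(dimethylamino)ethyl and 2-(diethylamino)ethyl amides give numbers.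

As far as these compounds go, whether the tertiary amine in those chains is what separates them from compound 3 and compound 4 remains open, and a 2-hydroxyethyl group or a primary aminoethyl group on the same nitrogen would bear on that question. From the compounds shown here alone, how far compound 3 and compound 4 each lie beyond the limit also remains open, and so does any ranking of their two groups.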